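Cytotoxicity notes on the aryl swap from compound 1

This account rests on a few compounds, and the source may have more. Where it says the series, first, only, none or still open, it means among the compounds named here.

For the measured compounds named here, compound 1 `Cc1ccccc1-c1nn(-c2ccc(Cl)cc2)cc1CNCCN1CCN(C)CC1` is the only member of this set with a number in an ADME assay on Huh-7 cells (Homo sapiens) for cytotoxicity (a lower number here means that less compound is tolerated, a higher number that more compound is tolerated), where compound 1 gives 17000 nM. Compound 2 `Cc1cccc(-c2nn(-c3ccc(F)cc3F)cc2CNCCN2CCN(C)CC2)c1` gives > 20000 nM, which is a limit of the assay. Compound 3 `CN1CCN(CCNCc2cn(-c3ccc(F)cc3F)nc2-c2ccc(S(=O)(=O)N(C)C)cc2)CC1` gives > 20000 nM, likewise a limit. The step that the two limits leave unreadable from compound 2 to compound 3 is therefore unreadable, both values sitting at the limit of > 20000 nM in this assay, at which 2 of the 3 values shown sit. Compound 4 `Cc1ccc(-n2cc(CNCCN3CCN(C)CC3)c(-c3ccccc3C)n2)c(C)c1` differs from compound 1 by 2,4-dimethylphenyl in place of 4-chlorophenyl on an aromatic nitrogen. Going by the values given here, no measured step bears on this change, and the only readable point is compound 1 itself. In this assay no shift beyond the scatter is expected, the step being estimated as no change at the digits printed from compound 1 to compound 4 (within the scatter). Compound 4 is estimated at 17000 nM, within 8000 nM to 40000 nM, with a fair chance that only a limit is returned.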

Compound 4, half-maximal cytotoxic concentration: > 20000 nM
Compound 4 ended at the assay's limit; the forecaster's own chance of this, stated with the estimate: 40%; middle value at least 1.1-fold (0.07 log units) from the limit.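

In this assay, for the compounds shown here, 2,4-dimethylphenyl in place of 4-chlorophenyl on the aromatic nitrogen gives the first step at this position (an at least 1.1-fold higher number from compound 1 to compound 4 (0.07 log units; that floor lies within the scatter)). As far as these compounds go, this change removes the chlorine without a fall in the number, but the value of compound 4 is a limit, so the true size of the step stays unknown. Compound 4 also moves the set further towards its ceiling: the limit of > 20000 nM in this assay, at which 3 of the 4 values shown sit.

From the compounds shown here alone, whether an amine or a carboxylic acid on this aryl group would give a readable number stays open. So does the effect of replacing the aryl group with a longer chain.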